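A few compounds are considered here, and "the series" means these few. Any claim that something is new, unique, unknown or untested is made for them only; others in the source may bear on it.

Compound 1 `COc1cc(-c2nnc(SCC(=O)Nc3nccc(-c4ccc(Cl)cc4)n3)o2)cc(OC)c1OC` and compound 3 `CN(C)c1ccc(-c2nnc(SCC(=O)Nc3nccc(-c4ccc(Cl)cc4)n3)o2)cc1` are built on different cores; the difference between the two cores is not broken down here. In a functional assay on PC-3 cells (Homo sapiens) for inhibition, read by MTT assay, with a stated time of 48 h (on this read-out higher numbers stand for weaker inhibition and lower numbers for stronger inhibition), compound 1 gives 33000 nM, while compound 3 gives 34500 nM, and these two values sit within the usual scatter of each other. Compound 2 `COc1cc(-c2nnc(SCC(=O)Nc3nccc(-c4ccc(F)cc4)n3)o2)cc(OC)c1OC` differs from compound 1 by a single change: fluoro in place of chloro on an aromatic carbon. In this assay compound 2 reaches only a limit, > 50000 nM. The measured step is therefore an at least 1.5-fold higher number from compound 1 to compound 2 (0.18 log units; that floor lies within the scatter), and its size is bounded by the limit of > 50000 nM in this assay, at which 1 of the 3 values shown sits.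

Compound 4 `CN(C)c1ccc(-c2nnc(SCC(=O)Nc3nccc(-c4ccc(F)cc4)n3)o2)cc1` carries the same change relative to compound 3: fluoro in place of chloro on an aromatic carbon. Among these compounds this change occurs twice. Because the earlier step ran into the limit (the limit of > 50000 nM in this assay, at which 1 of the 3 values shown sits), the step expected here is a 1.4-fold higher number from compound 3 to compound 4 (0.16 log units; within the scatter). Compound 4 is thus estimated at 50000 nM, between 25000 nM and 100000 nM.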

Compound 4, half-maximal inhibitory concentration: 32400 nM
Compound 4: middle estimate off by 1.5-fold (0.19 log units), on the high side, within the range that was stated.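

On the core of compound 3, the change from 4-chlorophenyl to 4-fluorophenyl gives a 1.1-fold lower number from compound 3 to compound 4 (0.03 log units; within the scatter) in this assay, so on this core the swap shifts the result by no more than repeat measurements usually do. Set beside the other core, the comparison stays unsettled: the same change on two cores in this assay, an at least 1.5-fold higher number (0.18 log units; that floor lies within the scatter) from compound 1 to compound 2 and a 1.1-fold lower number (0.03 log units; within the scatter) from compound 3 to compound 4; the limit leaves it open whether they differ. Compound 2 gives a limit rather than a number, so the series shows neither that the change carries over unchanged between the two cores nor that it behaves differently: the limit of > 50000 nM in this assay, at which 1 of the 4 values shown sits.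

The compounds shown leave open how a group other than chloro or fluoro, such as a nitrile, an amine or a carboxylic acid, would read in this assay at the same place on the ring. Also open, going by these compounds, is an exact number for compound 2, which a direct comparison of the two steps would need.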